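The source may hold more compounds than are shown below. What is called first, only, known or untested is meant among the compounds shown, and "the series" means these compounds.

Compound 1 `COc1ccc2c(=O)c(/C=C/C(=O)Nc3ccc(Cl)cc3)coc2c1` stands at the limit of a functional assay on HeLa cells (Homo sapiens) for inhibition, read by MTT assay, with a stated time of 48 h; on this read-out lower numbers stand for stronger inhibition and higher numbers for weaker inhibition: in this assay compound 1 gives > 100000 nM, a limit and not a number. Two of the three values shown sit at that limit (the limit of > 100000 nM in this assay, at which 2 of the 3 values shown sit). Compound 2 `Cc1ccccc1NC(=O)/C=C/c1coc2cc(O)ccc2c1=O` gives 8670 nM in this assay. Compound 3 `Cc1ccc(CNC(=O)/C=C/c2coc3cc(O)ccc3c2=O)cc1` gives > 100000 nM in this assay, also a limit. Going by the values given here, the one measured step, an at least 11-fold higher number from compound 2 to compound 3 (1.06 log units; beyond the scatter), is the change from 2-methylphenyl to 4-methylbenzyl on the amide-type nitrogen. Compound 4 `COc1ccc2c(=O)c(/C=C/C(=O)NCc3ccccc3F)coc2c1` differs from compound 1 by 2-fluorobenzyl in place of 4-chlorophenyl on an amide-type nitrogen, a change of the same kind, and that step weakened the number. Compound 1 already sits at the limit, so compound 4 is expected to stay there or beyond, with a step that the limit leaves unreadable from compound 1 to compound 4 expected. Compound 4 is estimated at 150000 nM, in the range 50000 nM to 500000 nM.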

Compound 4, half-maximal inhibitory concentration: > 100000 nM
Compound 4 was reported as a limit; the forecaster's own chance of this, stated with the estimate: 75%; the middle value lies beyond the limit too.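

Compound 1 and compound 4 are both limits, so no step can be read between them: the limit of > 100000 nM in this assay, at which 3 of the 4 values shown sit. Left open is how 2-fluorobenzyl and 4-chlorophenyl on the amide-type nitrogen compare on the core of compound 1.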